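Adding Fluorine to a Compound Showing No Inhibition

The compounds below may be only part of what the source reports. "The series", "measured", "known", "first", "only" and "open" are said of these compounds alone.

Of the compounds shown here, three have been tested in an assay on isolated protein for inhibition of Ca2+/calmodulin-dependent protein kinase II (CaM kinase II) (Rattus norvegicus), tested at 30 uM; on this read-out higher numbers stand for more inhibition at the one concentration tested (going by the name of the read-out) and lower numbers for less inhibition. Compound 1 `Fc1ccc(Nc2[nH]cnc3ncnc2-3)cc1` gives 2%. Compound 2 `c1ccc(Oc2ncnc3[nH]cnc23)cc1` gives 0%, and compound 3 `Cn1cnc2c(Nc3ccccc3)ncnc21` gives 0%. Compound 3 thus stands level with compound 2 at the digits shown, the two together being the lowest of the three numbers, and its distance to compound 1 lies within the usual scatter of repeated measurements, so none of the three can be told apart from the others on this read-out.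

Compound 4 `Cn1cnc2c(Nc3ccc(F)cc3)ncnc21` has not yet been measured in this assay. It differs from compound 3 in one place: fluoro in place of hydrogen on an aromatic carbon. The new fluorine sits on an aromatic carbon of a six-membered aromatic ring of carbon only, para to a large group.

Among the measured compounds shown here, no pair of measured compounds that differ in a single place is available, so the size of such a step is not known from these data. Compound 1 also carries a fluoro group on such a ring and gives 2%, which offers no sign that this group raises the number. The step from compound 3 to compound 4 is therefore expected to be a number 1 percentage points higher from compound 3 to compound 4 (within the scatter), no change beyond the scatter. Compound 4 is estimated to give 1%, with a likely range from -6% to 8%.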

Compound 4, a percentage reported as inhibition, at one concentration (the size of the read-out at that concentration, not a potency): 8%
Compound 4: middle estimate off by 7 percentage points, on the low side, and the stated range covers the measured number.
By their numbers in this assay, from the lowest: compounds 2, 3, 1 and 4 (each within the scatter of the next).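

Among the compounds shown here, compound 3 and compound 4 form the first pair in this assay that differs in a single place, so the effect of one change can now be read directly instead of being inferred from compounds that differ in several ways. Putting fluoro in place of hydrogen on an aromatic carbon of this six-membered ring, para to a large group, gives a number 8 percentage points higher from compound 3 to compound 4 (within the scatter) and so does not separate the two compounds on this read-out. At this position on this core, then, fluoro and hydrogen cannot be told apart, and nothing available here bears on why the number comes out as it does.

Going by these compounds, it remains open whether a different group at the same place, such as chloro, methoxy, an amine or a carboxylic acid, would move the number beyond the usual scatter. Also open, on these data alone, is whether the same fluoro change would read the same way on the core of compound 1 or at another concentration, where a clearer difference might or might not appear.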